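A few compounds are considered here, and "the series" means these few. Any claim that something is new, unique, unknown or untested is made for them only; others in the source may bear on it.

Measured compounds:
compound 1, `O=C(OC(CCCN1CCN(c2ncc(F)cn2)CC1)c1ccc(F)cc1)c1ccccc1`: 3500 nM
compound 2, `O=S(=O)(CCCN1CCN(c2ncc(F)cn2)CC1)c1ccc(F)cc1`: > 45 nM

Going by the values given here, in an assay (Cavia porcellus) for displacement of a labelled ligand from Sigma non-opioid intracellular receptor 1 (Homo sapiens) (on this read-out lower numbers stand for stronger inhibition and higher numbers for weaker inhibition), compound 1 gives 3500 nM, the only number reported in this set. The value shown for compound 2 is a limit of the assay and not a number, as noted in the limit of > 45 nM in this assay, at which 1 of the 2 values shown sits. Among the compounds with values here, no step between measured compounds that differ in one place is available, so the move to compound 3, `CC(=O)NC(CCCN1CCN(c2ncc(F)cn2)CC1)c1ccc(F)cc1`, rests on the structural change alone: acetamido in place of benzoyloxy on a saturated chain carbon bound to an aromatic carbon and a saturated chain carbon. Compound 1 already stands at a weak value, and the change exchanges a larger group for a smaller one, as counted. A step of moderate size toward weaker inhibition, or none beyond the usual scatter, is expected, written as a 1.7-fold higher number from compound 1 to compound 3 (0.23 log units; within the scatter). Compound 3 is therefore estimated at 6000 nM, with a range from 1500 nM to 25000 nM.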

Compound 3, half-maximal inhibitory concentration: > 49 nM
Compound 3 ended at the assay's limit; the forecaster's own chance of this, stated with the estimate: 40%; the middle value is on the limit's open side.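

Going by these compounds alone, no step from compound 1 to compound 3 can be read, because compound 3 stands at a limit of the assay and not at a number: the limit of > 49 nM in this assay, at which 1 of the 3 values shown sits. The compounds shown leave open whether acetamido in place of benzoyloxy shifts inhibition at all, and in which direction.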